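The source may hold more compounds than are shown below. What is called first, only, known or untested is meant among the compounds shown, and "the series" means these compounds.

The series shares the core of compound 1 `COc1ccc(-c2c(I)c(=O)c3c(OC)cc(OC)cc3n2S(=O)(=O)c2ccc(OC)cc2)cc1`, which in a functional assay on KOPN-8 cells (Homo sapiens) for antiproliferative activity, with a stated time of 72 h (a higher number here means that more compound is needed for the effect, a lower number that less compound is needed), gives 8580 nM. Compound 3 `COc1ccc(-c2cc(=O)c3c(OC)cc(OC)cc3n2S(=O)(=O)c2ccc([N+](=O)[O-])cc2)cc1` carries a 4-nitrophenyl on the sulfonyl sulfur and in this assay gives 17300 nM; this and the value of compound 1 lie within the usual scatter of one another, so no order between the two can be drawn. The smaller compound 2 `COC(=O)c1cc(=O)c2c(OC)cc(OC)cc2[nH]1` gives in this assay only a limit, > 34400 nM. Within the data shown here, no pair of the measured compounds differs in one place only, so no single step has been measured, and nothing tells how the group on the sulfonyl sulfur affects the number.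

Compound 4 `COc1ccc(-c2cc(=O)c3c(OC)cc(OC)cc3n2S(=O)(=O)c2cc(Cl)cc(Cl)c2O)cc1` differs from compound 3 by 3,5-dichloro-2-hydroxyphenyl in place of 4-nitrophenyl on a sulfonyl sulfur. Among the measured compounds shown here, with no measured step at this position to lean on, the step from compound 3 to compound 4 is expected to stay within the scatter, a 1.3-fold lower number from compound 3 to compound 4 (0.12 log units; within the scatter), in either direction. For compound 4 the estimate in this assay is 13000 nM, with a range from 4000 nM to 40000 nM.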

Compound 4, half-maximal effective concentration: > 37900 nM
Compound 4 gave a limit, no number (the forecaster's own chance of this, stated with the estimate: 30%); middle value at least 2.9-fold (0.46 log units) from the limit.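

Among these compounds, this is the only measured step at this position, and it shows that the number responds to the group on the sulfonyl sulfur: in this assay, 3,5-dichloro-2-hydroxyphenyl in place of 4-nitrophenyl gives an at least 2.1-fold higher number from compound 3 to compound 4 (0.34 log units; beyond the scatter). The earlier compounds shown here could not show this, as no pair of them differed in one place only. Compound 4 gives a limit and not a number, so the size of the step is bounded on one side only: the limit of > 37900 nM in this assay, at which 1 of the 4 values shown sits.

The two chlorines and the hydroxy group enter together, and the compounds shown do not separate their shares in the step. From the compounds shown here alone, whether an unsubstituted phenyl, or a phenyl carrying an amine or a carboxylic acid, would give a lower number than compound 3 at this position also stays open.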